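The source may report more compounds than this note shows. Statements on the series, on what has been measured and on what is new or still open speak of the compounds shown alone.

Compound 1 `C=C(Br)C(=O)Nc1ccc(/C=C2\SC(=O)N(Cc3cccc(Cl)c3)C2=O)cc1` gives 3700 nM in a functional assay on CCRF-CEM cells (Homo sapiens) for cytotoxicity, read by cell counting, with a stated time of 3 days; on this read-out higher numbers stand for weaker inhibition and lower numbers for stronger inhibition.
Compound 2 `C=C(Br)C(=O)Nc1ccc(/C=C2\SC(=O)N(Cc3ccc(C)cc3)C2=O)cc1` gives 3700 nM in this assay.
Compound 3 `Nc1cccc(/C=C2\SC(=O)N(Cc3cccc(F)c3)C2=O)c1` gives 250000 nM in this assay.

Compound 2 stands level with compound 1, and together they give the lowest numbers of the three, while compound 3 stands far higher, well beyond the scatter. Compound 4 `C=C(Br)C(=O)Nc1ccc(/C=C2\SC(=O)N(Cc3ccccc3)C2=O)cc1` has not been measured yet. It differs from compound 2 by hydrogen in place of methyl on an aromatic carbon. For the measured compounds named here, the one measured step that bears on this part of the structure, no change at the digits printed from compound 1 to compound 2 (within the scatter), swapped the whole group on the saturated chain carbon without moving the number. Removing a single methyl from the same place is expected to leave the number within the scatter as well, so the step of no change at the digits printed from compound 2 to compound 4 (within the scatter) is expected to be none beyond the scatter. Compound 4 is therefore estimated at 3700 nM, within a range from 1500 nM to 9000 nM.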

Compound 4, half-maximal inhibitory concentration: 2300 nM
Beside the measured number, compound 4's estimate is 1.6-fold (0.21 log units) above it; measured number inside the range.
By their numbers in this assay, from the lowest: compounds 4, 1 and 2 (each within the scatter of the next); then compound 3.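

Replacing the group on the ring with plain hydrogen gives a 1.6-fold lower number from compound 2 to compound 4 (0.21 log units; within the scatter) in this assay, and the same replacement of chloro gives a 1.6-fold lower number from compound 1 to compound 4 (0.21 log units; within the scatter). Among these compounds, then, the benzyl ring holds its level with neither a methyl nor a chloro, which the earlier pair, each carrying a substituent, could not show. Nothing available here explains this result. From the compounds shown here alone, whether an amine, a carboxylic acid or a longer chain on this ring would also stay within the scatter remains open.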